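The source may hold more compounds than are shown below. What is called first, only, known or untested is meant among the compounds shown, and "the series" means these compounds.

In an ADME assay on Vero cells (Chlorocebus sabaeus) for cytotoxicity, read by MTT assay, with a stated time of 96 h (a lower number here means that less compound is tolerated, a higher number that more compound is tolerated), compound 1 `C/C(=N\NC(N)=O)c1ccc2[nH]c(-c3ccccc3)nc2c1` gives only the limit > 100000 nM. Compound 2 `C/C(=N\NC(N)=O)c1ccc2c(c1)nc(-c1ccccc1)n2C1CCCCC1` likewise reaches only the limit > 100000 nM in this assay. The step that the two limits leave unreadable from compound 1 to compound 2 cannot be read because both values sit at the limit of > 100000 nM in this assay, at which 2 of the 2 values shown sit. Compound 3 `C/C(=N\NC(N)=O)c1ccc2c(c1)nc(-c1ccccn1)n2C1CCCCC1` differs from compound 2 by pyridin-2-yl in place of phenyl on an aromatic carbon. Within the data shown here, no measured step bears on this change, and the two limits give no size of step to expect in this assay. Compound 3 is therefore expected to give 100000 nM, within 50000 nM to 200000 nM, in this assay. The step of a number no higher from compound 2 to compound 3 (the limit leaves the size open) is estimated to stay within the scatter.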

Compound 3, half-maximal cytotoxic concentration: > 100000 nM
Compound 3: no number, only a limit (the forecaster's own chance of this, stated with the estimate: 80%); the middle value sits exactly at the limit.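

Among these compounds, compound 2 and compound 3 both give only a limit in this assay, so no step between them can be read: the limit of > 100000 nM in this assay, at which 3 of the 3 values shown sit. The compounds shown leave open at what concentration any of them would become cytotoxic, and whether pyridin-2-yl in place of phenyl alters that concentration.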